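Dropping one chloro from a dichlorophenyl ether

This account rests on a few compounds, and the source may have more. Where it says the series, first, only, none or still open, it means among the compounds named here.

Of the compounds shown here, two built on a shared core have been measured in an assay on isolated protein for inhibition of Dihydrofolate reductase (Homo sapiens), read by spectrophotometry, using NADPH, with stated times of 5 s and 6 min, tested at 5 uM; on this read-out lower numbers stand for a weaker effect and higher numbers for a stronger effect at the one concentration tested. Compound 1 `NC1=NC2(CCOCC2)N(OCCCOc2cccc(Cl)c2Cl)C(N)=N1` gives 81.7% in this assay, and compound 2 `NC1=NC2(CCSCC2)N(OCCCOc2ccccc2Cl)C(N)=N1` gives 86.3%. Of the two numbers shown, compound 1 stands at the smaller one, but its gap to compound 2 lies within the usual scatter of repeated measurements, so the two compounds cannot be told apart on these data.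

Compound 3 `NC1=NC2(CCOCC2)N(OCCCOc2cccc(Cl)c2)C(N)=N1` has not yet been measured in this assay. It differs from compound 1 in one place: hydrogen in place of chloro on an aromatic carbon. Among the measured compounds shown here, no pair of measured compounds differs in a single place, so nothing measured here shows the size of such a change; compound 2 differs from compound 1 in more than one place, and only its two values stand beside each other.

The step of a number 9.7 percentage points lower from compound 1 to compound 3 (within the scatter) is therefore expected to be a modest weakening, close to the edge of the scatter. Compound 3 is expected to give 72%, with a range from 55% to 85%.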

Compound 3, a percentage reported as inhibition, at one concentration (the size of the read-out at that concentration, not a potency): 83.2%
Compound 3: the middle estimate sits 11.2 percentage points below what was measured; measured number inside the range.
By their numbers in this assay, from the lowest: compounds 1, 3 and 2 (each within the scatter of the next).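

Among the compounds shown here, the swap of 2,3-dichlorophenyl to 3-chlorophenyl gives the first comparison here that differs in one place only, and in this assay it reads as a number 1.5 percentage points higher from compound 1 to compound 3 (within the scatter) on this single change. At this position, an aromatic carbon ortho to a chloro group, hydrogen in place of chloro therefore leaves no difference that this read-out can separate at the one concentration tested, so the chloro that leaves is not shown to matter for the inhibition seen here. Nothing measured on these compounds speaks to why the two read alike.

Still open, from the compounds shown here alone, is whether the 3-chlorophenyl group of compound 3 could lose its remaining chloro as well, and whether an amine, a methoxy group or a carboxylic acid on the carbon that now carries hydrogen would read the same. Also open, going by these compounds, is whether the same change would read alike on the core of compound 2, and whether the single concentration conceals a difference in potency between compound 1 and compound 3.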